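This account rests on a few compounds, and the source may have more. Where it says the series, first, only, none or still open, it means among the compounds named here.

In a functional assay on A549 cells (Homo sapiens) for inhibition, read by MTT assay, with a stated time of 24 h (a lower number here means a stronger inhibitor, a higher number a weaker inhibitor), compound 1 `CC1(C)[C@H]2CC[C@]1(C)N(Cc1cn(-c3cccc(F)c3)nn1)C(=O)C2` gives 180 nM, compound 2 `CC1(C)[C@H]2CC[C@]1(C)N(Cc1cn(-c3ccc(C#N)cc3)nn1)C(=O)C2` gives 140 nM and compound 3 `Cc1ccccc1-n1cc(CN2C(=O)C[C@@H]3CC[C@@]2(C)C3(C)C)nn1` gives 90 nM. Compound 3 therefore stands level with the other two, its number lying within the scatter of both. Compound 4 `CC1(C)[C@H]2CC[C@]1(C)N(Cc1cn(-c3ccc(Cl)cc3)nn1)C(=O)C2` has 4-chlorophenyl in place of 2-methylphenyl on an aromatic nitrogen. Three measured steps change the group at this same place: a 1.3-fold lower number from compound 1 to compound 2 (0.11 log units; within the scatter), a 2.0-fold lower number from compound 1 to compound 3 (0.30 log units; within the scatter) and a 1.6-fold lower number from compound 2 to compound 3 (0.19 log units; within the scatter). All three lie within the scatter, although none of them brings in 4-chlorophenyl itself. No change beyond the scatter is therefore expected in this assay. The expected step is a 1.4-fold higher number from compound 3 to compound 4 (0.16 log units; within the scatter). Compound 4 is estimated at 130 nM, with an expected range from 60 nM to 300 nM.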

Compound 4, half-maximal inhibitory concentration: 70 nM
Compound 4: the middle estimate sits 1.9-fold (0.27 log units) above what was measured; measured number inside the range.
By their numbers in this assay, from the lowest: compounds 4, 3, 2 and 1 (each within the scatter of the next, the first and the last beyond it).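

In this assay, within the data shown here, 4-chlorophenyl in place of 3-fluorophenyl on the aromatic nitrogen gives the first step at this place that lies beyond the scatter, though only a modest one (a 2.6-fold lower number from compound 1 to compound 4 (0.41 log units; beyond the scatter)). The two other new steps stay within the scatter (a 1.3-fold lower number from compound 3 to compound 4 (0.11 log units; within the scatter); a 2.0-fold lower number from compound 2 to compound 4 (0.30 log units; within the scatter)), so 4-chlorophenyl, 2-methylphenyl and 4-cyanophenyl stand level here. No measurement available here accounts for this step. The compounds shown leave open how a phenyl ring carrying an amine or a carboxylic acid would compare at this place.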